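The source may hold more compounds than are shown below. What is called first, only, known or untested is meant among the compounds shown, and "the series" means these compounds.

Compound 1 `COc1cc(OC)c(OC)cc1/C=C/C(=O)c1ccccc1`: 2.23 ug/mL
Compound 2 `COc1cc(C(=O)/C=C/c2cc(OC)c(OC)cc2OC)ccc1O`: 2.16 ug/mL
Compound 3 `COc1cc(OC)c(OC)cc1/C=C/C(=O)c1cccc(C(F)(F)F)c1`: 2.3 ug/mL

All three were measured in a functional assay on cells (Erythrocyte, Rattus norvegicus) for inhibition, read by hemolysis, with a stated time of 1 h; on this read-out lower numbers stand for stronger inhibition and higher numbers for weaker inhibition. On these numbers compound 1 stands second highest of three, and both of its neighbours lie within the scatter: the step of a 1.0-fold higher number from compound 1 to compound 3 (0.01 log units; within the scatter) is within the scatter, and the values of compound 1 and compound 2 differ by no more than the scatter as well. Nothing among the three compounds therefore separates them.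

Compound 4 `COc1cc(OC)c(OC)cc1/C=C/C(=O)c1ccc(Br)cc1` has not yet been measured. It differs from compound 1 in one place: bromo in place of hydrogen on an aromatic carbon. Among the compounds with values here, the only measured step that bears on this change is a 1.0-fold higher number from compound 1 to compound 3 (0.01 log units; within the scatter), where a trifluoromethyl entered the same ring of the shared core in place of hydrogen and left the number where it was. On that basis compound 4 is expected to sit close to compound 1, with a step of a 1.0-fold higher number from compound 1 to compound 4 (0.01 log units; within the scatter) that stays within the scatter. Compound 4 is estimated at 2.3 ug/mL, between 1.2 ug/mL and 4.5 ug/mL.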

Compound 4, half-maximal inhibitory concentration: 2.3 ug/mL
Compound 4: middle estimate and measured number agree at the digits printed, and the stated range covers the measured number.
By their numbers in this assay, from the lowest: compounds 2, 1, 3 and 4 (each within the scatter of the next).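

With the step of a 1.0-fold higher number from compound 1 to compound 4 (0.01 log units; within the scatter) in this assay, this result shows that a change at the ring carbon para to a large group also leaves the number within the scatter. It also extends the picture beyond the trifluoromethyl of compound 3 at another carbon of the same ring: a single bromine atom at this position, replacing hydrogen, does not separate compound 4 from compound 1. Nothing available gives a reason for this result.

The compounds shown leave open whether an amine or a carboxylic acid on this same carbon would stay within the scatter of compound 1. They also do not show whether any group at this position can move the number beyond the scatter.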